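Compound 3 to compound 4: a change on the aryl group

The source may report more compounds than this note shows. Statements on the series, on what has been measured and on what is new or still open speak of the compounds shown alone.

Values in an ADME assay on microsomes from liver (Canis lupus familiaris) for metabolic stability (on this read-out higher numbers stand for a longer-lived compound and lower numbers for a shorter-lived compound), all of them limits:
- Compound 1 `N#Cc1ccc(NCCNc2ncc(-c3ncc[nH]3)c(-c3ccc(Cl)cc3Cl)n2)nc1` gives > 0.5 h, a limit.
- Compound 2 `FC(F)(F)c1ccc(NCCNc2ncc(-c3ncc[nH]3)c(-c3ccc(Cl)cc3Cl)n2)nc1` gives > 0.5 h, a limit.
- Compound 3 `Nc1nc(NCCNc2ncc(-c3ncc[nH]3)c(-c3ccccc3Cl)n2)ccc1[N+](=O)[O-]` gives > 0.5 h, a limit.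

The next compound to be read is compound 4 `Nc1nc(NCCNc2ncc(-c3ncc[nH]3)c(-c3cc(F)ccc3F)n2)ccc1[N+](=O)[O-]`, which has no value yet. Compound 3 has only a limit to stand on, with no number behind it. The whole series offers only (the limit of > 0.5 h in this assay, at which 3 of the 3 values shown sit), and no ranking of the three compounds can be drawn from it.

The change is 2,5-difluorophenyl in place of 2-chlorophenyl on an aromatic carbon, on the shared core: 2,5-difluorophenyl in place of 2-chlorophenyl on an aromatic carbon.

One measured step exists, a step that the two limits leave unreadable from compound 1 to compound 2. It is trifluoromethyl in place of cyano on an aromatic carbon, a swap of other groups, and its size cannot be read. Among the compounds with values here, it therefore gives no guidance on size or direction, and no measured step covers this aryl exchange.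

With no evidence for a shift in either direction, no step beyond the scatter is expected in this assay. The expected step is a step that the limit leaves unreadable from compound 3 to compound 4. Another report as a limit is the likeliest outcome. Compound 4 is estimated at 0.7 h, with an expected range from 0.4 h to 1.5 h.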

Compound 4, half-life: > 0.5 h
Compound 4 was reported as a limit; the forecaster's own chance of this, stated with the estimate: 75%; the middle value is on the limit's open side.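

In this assay, within the data shown here, compound 3 and compound 4 are both reported only as limits, so no step between them can be read. The series offers a single reading: the limit of > 0.5 h in this assay, at which 4 of the 4 values shown sit.

From the compounds shown here alone, whether 2,5-difluorophenyl in place of 2-chlorophenyl changes the half-life at all, in either direction or by any size, stays open.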